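Swapping the Five-Membered Ring on a Shared Core

A few compounds are considered here, and "the series" means these few. Any claim that something is new, unique, unknown or untested is made for them only; others in the source may bear on it.

Three compounds have been measured in a functional assay on HepG2 cells (Homo sapiens) for antiproliferative activity, read by MTT assay, with a stated time of 72 h; a lower number here means a stronger inhibitor, a higher number a weaker inhibitor:
compound 1 `CN1CCC(NC(=O)c2ccc(Cn3nc(-c4cnn(C)c4)c4ccccc4c3=O)cc2)CC1` gives 47300 nM
compound 2 `Cn1cc(-c2nn(Cc3ccc(C(=O)NC4CCCC4)cc3)c(=O)c3ccccc23)cn1` gives 84300 nM
compound 3 `Cc1noc(C)c1-c1nn(Cc2ccc(C(=O)NC3CC(C)(C)N([O])C(C)(C)C3)cc2)c(=O)c2ccccc12` gives 85100 nM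

Compound 3 gives the highest of these three numbers, yet its gaps to compound 2 and to compound 1 both lie within the scatter, so the three compounds cannot be told apart on these data. For the measured compounds named here, only one step between compounds differing in a single place has been measured: a 1.8-fold higher number from compound 1 to compound 2 (0.25 log units; within the scatter), a change on the amide-type nitrogen that stays within the scatter.

Compound 4 `Cn1cc(-c2nn(Cc3ccc(C(=O)NC4CC(C)(C)N([O])C(C)(C)C4)cc3)c(=O)c3ccccc23)cn1` differs from compound 3 by 1-methyl-1H-pyrazol-4-yl in place of 3,5-dimethyl-1,2-oxazol-4-yl on an aromatic carbon. Going by the values given here, this exchange at the aromatic carbon has no measured counterpart; the one measured step concerns a different part of the molecule. What the data do show is that compounds 1 and 2, both carrying the 1-methyl-1H-pyrazol-4-yl group, and compound 3, carrying the 3,5-dimethyl-1,2-oxazol-4-yl group, all give numbers within the scatter of one another. The step from compound 3 to compound 4 is therefore expected to be a 1.1-fold lower number from compound 3 to compound 4 (0.03 log units; within the scatter), that is, nothing beyond the scatter. Compound 4 is estimated at 80000 nM, with a range from 35000 nM to 180000 nM.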

Compound 4, half-maximal inhibitory concentration: 27400 nM
Estimate against measurement, compound 4: 2.9-fold (0.47 log units) above; measured number outside the range, below it.
By their numbers in this assay, from the lowest: compounds 4, 1, 2 and 3 (each within the scatter of the next, the first and the last beyond it).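

In this assay, the aromatic carbon of the shared core proves sensitive to the ring it carries: with the amide side held constant, 1-methyl-1H-pyrazol-4-yl in place of 3,5-dimethyl-1,2-oxazol-4-yl gives a 3.1-fold lower number from compound 3 to compound 4 (0.49 log units; beyond the scatter) even though both groups are five-membered aromatic rings with 2 hetero atoms. The amide nitrogen can matter too, as with the 1-methyl-1H-pyrazol-4-yl group held constant, the group of 11 heavy atoms in place of cyclopentyl gives a 3.1-fold lower number from compound 2 to compound 4 (0.49 log units; beyond the scatter) while the same group in place of 1-methylpiperidin-4-yl gives a 1.7-fold lower number from compound 1 to compound 4 (0.24 log units; within the scatter) and so does not separate those two compounds. No measurement at hand accounts for either effect.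

From the compounds shown here alone, the exchange at the aromatic carbon is seen on a single amide group, so whether the same difference appears with cyclopentyl or 1-methylpiperidin-4-yl on the amide nitrogen remains open. Also open is how a phenyl ring on this aromatic carbon, or a simple primary amine on the amide side, would compare with the groups shown here.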